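Trimming the side chain: from hydroxymethyl to bare hydrogen

This account rests on a few compounds, and the source may have more. Where it says the series, first, only, none or still open, it means among the compounds named here.

Of the compounds shown here, two sharing one core have been measured in a functional assay on HT cells (Homo sapiens) for antiproliferative activity, read by fluorescence, with a stated time of 72 h; on this read-out higher numbers stand for weaker inhibition of growth and lower numbers for stronger inhibition of growth. Compound 1 `CC(C)c1n[nH]c2c(NCc3ccc(-c4ccccn4)cc3)nc(SCC(N)CN)nc12` gives 480 nM, while compound 2 `CC(C)c1n[nH]c2c(NCc3ccc(-c4ccccn4)cc3)nc(SCCO)nc12` gives 48 nM, the lower of the two numbers; the step of a 10-fold lower number from compound 1 to compound 2 (1.00 log units; beyond the scatter) separates them. Compound 3 `CSc1nc(NCc2ccc(-c3ccccn3)cc2)c2[nH]nc(C(C)C)c2n1` is the next candidate. It differs from compound 2 by hydrogen in place of hydroxymethyl on a saturated chain carbon bound to a sulfur. Among the measured compounds shown here, only one measured step exists, and it concerns a different exchange at the same place, so it offers weak guidance: it shows that the group on this chain carbon can shift the read-out considerably. Removing the hydroxymethyl altogether may move the number either way. The expected change is a 1.6-fold higher number from compound 2 to compound 3 (0.19 log units; within the scatter), small in size. For compound 3 the estimated value in this assay is 75 nM, with a likely range from 20 nM to 280 nM.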

Compound 3, concentration for 50% growth inhibition: 783 nM
Compound 3: middle estimate off by 10-fold (1.02 log units), on the low side; measured number outside the range, above it.
By their numbers in this assay, from the lowest: compound 2; then compounds 1 and 3 (each within the scatter of the next).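

On this assay the exchange of hydroxymethyl for hydrogen gives a 16-fold higher number from compound 2 to compound 3 (1.21 log units; beyond the scatter) and so shows that the methylsulfanyl group does not keep the stronger growth inhibition seen with the (2-hydroxyethyl)sulfanyl group. The earlier step showed only that hydroxymethyl gave a lower number than 1,2-diaminoethyl, whereas removing the group altogether gives a 1.6-fold higher number from compound 1 to compound 3 (0.21 log units; within the scatter) and leaves the two compounds indistinguishable. Among these three compounds, only the 2-hydroxyethyl chain of compound 2 gives the low number, and neither the chain carrying two amines nor the bare methyl matches it.

From the compounds shown here alone, whether the hydroxyl itself or simply the length of the chain matters stays open, and a 2-methoxyethyl or a plain ethyl group in this place would help separate the two. No measurement shown here explains the size of this step.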